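Solubility notes on the step from compound 3 to compound 4

The source may report more compounds than this note shows. Statements on the series, on what has been measured and on what is new or still open speak of the compounds shown alone.

Measured so far in a physicochemical assay for solubility, using the shake flask method, in simulated intestinal fluid, measured as kinetic solubility, with a stated time of 2 h, at 25 degrees C, at pH 6.5; a lower number here means a less soluble compound, a higher number a more soluble compound:
compound 1 `Cc1noc(-c2nc(C)c3c(c2N)C(=O)N(Cc2ccc(-c4ccncc4)cc2)C3=O)n1`: < 5000 nM
compound 2 `Cc1noc(-c2nc(C)c3c(c2N)C(=O)N(C(C)c2ccccc2)C3=O)n1`: 10900 nM
compound 3 `Cc1noc(-c2nc(C)c3c(c2N)C(=O)N(Cc2ccccc2Cl)C3=O)n1`: < 5000 nM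

Compound 3 reports only a limit in this assay, (the limit of < 5000 nM in this assay, at which 2 of the 3 values shown sit); a number is not known for it. For the measured compounds named here, the single measured step, an at least 2.1-fold lower number from compound 2 to compound 3 (0.33 log units; beyond the scatter), concerns a different exchange on the same nitrogen and does not cover the change now considered. Compound 4 `Cc1noc(-c2nc(C)c3c(c2N)C(=O)N(Cc2ccc(CO)cc2)C3=O)n1` differs from compound 3 by 4-(hydroxymethyl)phenyl in place of 2-chlorophenyl on a saturated chain carbon bound to an amide-type nitrogen in a ring. No measured pair in this series tests a hydroxymethyl group, so the direction rests on no shown step. The expectation for compound 4 is a number rather than a limit, with an at least 1.6-fold higher number from compound 3 to compound 4 (0.20 log units; that floor lies within the scatter) estimated, though the wide range reflects that nothing measured anchors it. The estimate for compound 4 is 8000 nM, within 3000 nM to 25000 nM.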

Compound 4, solubility: < 5000 nM
Compound 4 ended at the assay's limit; the forecaster's own chance of this, stated with the estimate: 40%; at least 1.6-fold (0.20 log units) between middle value and limit.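

In this assay, 4-(hydroxymethyl)benzyl in place of 1-phenylethyl on the amide-type nitrogen gives an at least 2.1-fold lower number from compound 2 to compound 4 (0.33 log units; beyond the scatter), matching the direction of the 2-chlorobenzyl exchange. Compound 4 reports only a limit, < 5000 nM, not a number. The steps to compound 4 from compound 1 and compound 3 cannot be read, and the series now gathers at one limit: the limit of < 5000 nM in this assay, at which 3 of the 4 values shown sit.

As far as these compounds go, how compound 1, compound 3 and compound 4 rank remains unknown. Also open, from the compounds shown here alone, is whether an amine or a carboxylic acid in place of hydroxymethyl would give a number rather than a limit.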